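A Second Methoxy on Compound 2

The source may hold more compounds than are shown below. What is called first, only, known or untested is meant among the compounds shown, and "the series" means these compounds.

In a functional assay on HCT-116 cells (Homo sapiens) for cytotoxicity, read by crystal violet staining, with a stated time of 7 days (a higher number here means a weaker inhibitor, a lower number a stronger inhibitor), compound 2 (`COc1ccc2c(c1)C=C(C(=O)/C=C/c1ccccc1OC)CO2`) gives 1620 nM and stands in the middle of the three measured compounds. Compound 1 (`COc1cc(/C=C/C(=O)C2=Cc3cc(OC)ccc3OC2)cc(OC)c1`) is stronger with 330 nM as its value, while compound 3 (`COc1ccc(C(=O)/C=C/C2=Cc3ccc(OC)cc3OC2)cc1`) is weaker with 10500 nM as its value. Compound 4 (`COc1ccc2c(c1)C=C(C(=O)/C=C/c1ccc(OC)cc1OC)CO2`) arises from compound 2 by a single change, methoxy in place of hydrogen on an aromatic carbon. For the measured compounds named here, no measured pair shows this change alone. Compound 1 (330 nM) also carries two methoxy groups on that aromatic ring, which offers only indirect support. A modest strengthening is expected in this assay with an estimated 1.8-fold lower number from compound 2 to compound 4 (0.26 log units; within the scatter) that may not clear the scatter. For compound 4 the estimated value is 900 nM with 250 nM to 3500 nM as the expected range.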

Compound 4, half-maximal inhibitory concentration: 3970 nM
For compound 4 the middle estimate is 4.4-fold (0.64 log units) below the measured one; the whole stated range lies below it.
By their numbers in this assay, from the lowest: compound 1; then compound 2; then compound 4; then compound 3.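

In this assay, for the compounds shown here, methoxy in place of hydrogen on this aromatic carbon, meta to a methoxy group and para to a large group, gives a 2.5-fold higher number from compound 2 to compound 4 (0.39 log units; beyond the scatter) and so a modest weakening, the first direct reading of this change. On compound 2, then, the added methoxy at this position brings no gain. No evidence at hand accounts for the loss. From the compounds shown here alone, whether fluorine or an amine on the same carbon would fare differently stays open. So does whether this change would give the same step on another compound.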